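The compounds below may be only part of what the source reports. "The series", "measured", "known", "first", "only" and "open" are said of these compounds alone.

Compound 2 `COc1ccc(C(=O)N2CCC(n3cncc3-c3ccc(OS(=O)(=O)c4cccc5cnccc45)cc3)CC2)cc1` gives 77 nM in an assay on HEK293 cells for antagonist activity at P2X purinoceptor 7 (Homo sapiens), read by fluorescence, with a stated time of 2 h (on this read-out lower numbers stand for stronger inhibition and higher numbers for weaker inhibition), and compound 1 `O=C(c1ccc(Cl)c(C(F)(F)F)c1)N1CCC(n2cncc2-c2ccc(OS(=O)(=O)c3cccc4cnccc34)cc2)CC1` gives 45 nM; the step of a 1.7-fold higher number from compound 1 to compound 2 (0.23 log units; within the scatter) lies within the scatter, so the two numbers cannot be told apart. Compound 3 `O=C(c1ccc(Oc2ccccc2)cc1)N1CCC(n2cncc2-c2ccc(OS(=O)(=O)c3cccc4cnccc34)cc2)CC1` differs from compound 2 by phenyl in place of methyl on an oxygen on an aromatic ring. For the measured compounds named here, the one measured step, a 1.7-fold higher number from compound 1 to compound 2 (0.23 log units; within the scatter), exchanged the whole aromatic group on the carbonyl and stayed within the scatter; no measured pair touches the group on the ring oxygen. The step of a 1.1-fold lower number from compound 2 to compound 3 (0.04 log units; within the scatter) is therefore expected to stay within the scatter. Compound 3 is estimated at 70 nM, with a range from 25 nM to 200 nM.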

Compound 3, half-maximal inhibitory concentration: 187 nM
Compound 3: the middle estimate sits 2.7-fold (0.43 log units) below what was measured; low and high end bracket the measured number.
By their numbers in this assay, from the lowest: compounds 1 and 2 (each within the scatter of the next); then compound 3.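

In this assay, the group on this oxygen does count: going from methoxy to phenoxy gives a 2.4-fold higher number from compound 2 to compound 3 (0.39 log units; beyond the scatter), a modest step but the first in this short series that lies beyond the scatter. The change adds one six-membered aromatic ring of carbon only, with no hydrogen-bond donors or acceptors, and inhibition weakens. No measurement here explains this shift. From the compounds shown here alone, what an ethyl or a benzyl group on the same oxygen would give stays open, as does whether a hydroxyl group there would move the number at all.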